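Ring size on the aromatic nitrogen: cyclobutyl to cyclopropyl

A few compounds are considered here, and "the series" means these few. Any claim that something is new, unique, unknown or untested is made for them only; others in the source may bear on it.

Compound 1 `Nc1ncnc2c1c(Oc1cccc(C(F)(F)F)c1)nn2[C@H]1C[C@H](O)C1`: 1.25 h
Compound 2 `N#Cc1ccnc(Oc2nn(C3CCC3)c3ncnc(N)c23)c1`: 2.35 h
Compound 3 `Nc1ncnc2c1c(Oc1cc(C(F)(F)F)ccn1)nn2C1CCC1`: 1.02 h

Of the compounds shown here, three sharing one core have been measured in an ADME assay on microsomes from liver (Homo sapiens) for metabolic stability, read by LC-MS, using NADPH, with a stated time of 10 min, tested at 10 uM; a higher number here means that the compound lasts longer, a lower number that the compound disappears faster. Compound 3 gives 1.02 h, the lowest of the three numbers. Compound 1 gives 1.25 h, which lies within the scatter of compound 3, so no order between them can be claimed. For the measured compounds named here, compound 2 gives 2.35 h, and the one step that differs in a single place, a 2.3-fold lower number from compound 2 to compound 3 (0.36 log units; beyond the scatter), is beyond the scatter.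

Compound 4 `Nc1ncnc2c1c(Oc1cc(C(F)(F)F)ccn1)nn2C1CC1` is the next compound, not yet measured. It differs from compound 3 in one place: cyclopropyl in place of cyclobutyl on an aromatic nitrogen. Going by the values given here, none of the measured steps concerns a change of the ring on the aromatic nitrogen; the step from compound 2 to compound 3 concerns the group on the aromatic carbon, and compound 1 differs from compound 3 in two places at once. With nothing bearing on this change, no step beyond the scatter is expected, and compound 4 is estimated at 1 h (range 0.5 h to 2 h), which means an expected step of a 1.0-fold lower number from compound 3 to compound 4 (0.01 log units; within the scatter).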

Compound 4, half-life: > 2.41 h
Compound 4 gave a limit, no number; the forecaster's own chance of this, stated with the estimate: 5%; at least 2.4-fold (0.38 log units) between middle value and limit.
By their numbers in this assay, from the lowest: compounds 3, 1 and 2 (each within the scatter of the next, the first and the last beyond it). At a limit, above all of these: compound 4.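

In this assay compound 4 gives > 2.41 h, which is a limit of the assay and not a number. The earlier compounds shown here said nothing about the ring on the aromatic nitrogen, and this result shows that the ring counts at this position: cyclopropyl in place of cyclobutyl gives an at least 2.3-fold higher number from compound 3 to compound 4 (0.37 log units; beyond the scatter). The full size of that step cannot be read, as the result is known only as a limit: the limit of > 2.41 h in this assay, at which 1 of the 4 values shown sits.

The compounds shown leave open whether the same change would hold with the nitrile of compound 2 in place of trifluoromethyl. They also leave open how a cyclopentyl ring, an isopropyl group or an oxetane on the same nitrogen would compare with cyclopropyl, and what lies behind the step.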